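The source may hold more compounds than are shown below. What is called first, only, known or untested is meant among the compounds shown, and "the series" means these compounds.

In a functional assay on the whole organism for inhibition, with Rattus norvegicus as the target (on this read-out higher numbers stand for an effect only at larger amounts of compound and lower numbers for an effect already at smaller amounts), compound 1 `CC(C)c1ccc(OC(Cc2ccc(Cl)cc2)C(=O)O)cc1` gives 10 mg/kg. Compound 2 `Cc1ccc(CC(Oc2ccc(C(C)C)cc2)C(=O)O)cc1`, with methyl in place of chloro on an aromatic carbon, is reported only as a limit, < 50 mg/kg. Among the measured compounds shown here, the one measured step, a step that the limit leaves unreadable from compound 1 to compound 2, therefore has no readable size or direction. Compound 3 `COc1ccc(CC(Oc2ccc(C(C)C)cc2)C(=O)O)cc1` puts methoxy in place of methyl on an aromatic carbon. For the measured compounds named here, with no sized step to guide it, no change beyond the usual scatter is expected, and a step that the limit leaves unreadable from compound 2 to compound 3 is only an estimate. The expectation rests on compound 1 at 10 mg/kg. Compound 3 is expected at 15 mg/kg, with an estimated range of 4 mg/kg to 50 mg/kg.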

Compound 3, dose for half-maximal effect: > 50 mg/kg
Compound 3: a limit, no number; the forecaster's own chance of this, stated with the estimate: 25%; at least 3.3-fold (0.52 log units) between middle value and limit.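

Methoxy in place of chloro gives the first step of readable size at this position, para to a large group: in this assay there is an at least 5.0-fold higher number from compound 1 to compound 3 (0.69 log units; beyond the scatter), so compound 3 needs a larger dose than compound 1 for the same effect. The value of compound 3, > 50 mg/kg, is a limit. For methoxy in place of methyl there is a number no lower from compound 2 to compound 3 (the limit leaves the size open), and the size of the steps that involve compound 2 cannot be read.

Where methyl stands relative to chloro and methoxy therefore stays open. So does whether fluoro or an amine at this same position would give a dose like that of compound 1.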